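Bromophenyl for methylphenyl on the pyrazole-type nitrogen of compound 2

The source may report more compounds than this note shows. Statements on the series, on what has been measured and on what is new or still open speak of the compounds shown alone.

Of the compounds shown here, three of the shared core have been measured so far in a functional assay on DU-145 cells (Homo sapiens) for cytotoxicity, read by MTT assay, with a stated time of 48 h; on this read-out lower numbers stand for stronger inhibition and higher numbers for weaker inhibition. Compound 1, `CCOC(=O)c1c(-c2c(Cl)c3cc(C)ccc3oc2=O)nn(-c2ccccc2)c1C(=O)OCC`, gives 50000 nM in this assay. Compound 2, `COC(=O)c1c(-c2cc3ccccc3oc2=O)nn(-c2cccc(C)c2)c1C(=O)OC`, gives 35000 nM in this assay. Compound 3, `CCOC(=O)c1c(-c2cc3ccccc3oc2=O)nn(-c2ccc(Cl)cc2)c1C(=O)OCC`, gives 26000 nM in this assay. All three numbers are high, and compound 2 sits in the middle of them: its gap to compound 3 and its gap to compound 1 both fall inside the usual scatter, so no order among the three can be read from these data.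

Compound 4, `COC(=O)c1c(-c2cc3ccccc3oc2=O)nn(-c2ccc(Br)cc2)c1C(=O)OC`, has not yet been measured. It differs from compound 2 in one place: 4-bromophenyl in place of 3-methylphenyl on an aromatic nitrogen. Among the compounds with values here, compound 3 already carries a halogen on the same ring of its aryl substituent and its number in this assay lies inside the scatter of compound 2, which is the closest hint available for a halogen in that position; the ester chain length, however, also differs there, so no clean step exists.

The step from compound 2 to compound 4 in this assay is therefore expected to be small, a 1.2-fold lower number from compound 2 to compound 4 (0.07 log units; within the scatter), in no firm direction. Compound 4 is estimated to give 30000 nM in this assay, with a range from 12000 nM to 75000 nM.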

Compound 4, half-maximal inhibitory concentration: 93000 nM
Estimate against measurement, compound 4: 3.1-fold (0.49 log units) below; measured number above the stated range.
By their numbers in this assay, from the lowest: compounds 3, 2, 1 and 4 (each within the scatter of the next, the first and the last beyond it).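

In this assay, within the data shown here, the aryl group on the aromatic nitrogen is the first place where a single change can be read, and the number there does respond to that change: the step is a 2.7-fold higher number from compound 2 to compound 4 (0.42 log units; beyond the scatter) and runs towards weaker inhibition. The two groups have the same heavy-atom count and neither has hydrogen-bond donors or acceptors, so those counts do not separate 3-methylphenyl from 4-bromophenyl, yet the number still moves beyond the scatter. Nothing available accounts for this step.

The swap alters both the substituent and where it sits on the phenyl ring, so this one step cannot say which of the two matters; 3-bromophenyl and 4-methylphenyl on the same nitrogen, with the methoxycarbonyl groups kept, would separate them. From the compounds shown here alone, how far this aryl effect carries over to other parts of the shared core also stays open, for example with a carboxylic acid or an amide in place of the methoxycarbonyl groups.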